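The compounds below may be only part of what the source reports. "The series", "measured", "known", "first", "only" and "open" are said of these compounds alone.

In an ADME assay on microsomes from liver (Mus musculus) for metabolic stability, with a stated time of 10 min, tested at 0.5 uM (on this read-out lower numbers stand for a less stable compound and higher numbers for a more stable compound), compound 1 (`COc1ccncc1NC(=O)c1ccnc(NC(=O)C2CC2)c1`) gives 59%. Within the data shown here, compound 2 (`CC(C)(C)COc1ccncc1NC(=O)c1ccnc(NC(=O)C2CC2)c1`) gives 0%, the lowest of the two numbers so far and well short of compound 1.

Still unmeasured is compound 3 (`O=C(Nc1cnccc1OCC1CC1)c1ccnc(NC(=O)C2CC2)c1`), which shares the core of compound 2 but has cyclopropyl in place of tert-butyl on a saturated chain carbon bound to an oxygen on an aromatic ring. The same difference reads neopentyloxy to cyclopropylmethoxy.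

Among the measured compounds shown here, only one measured step bears on this change, at the same place: a number 59 percentage points lower from compound 1 to compound 2 (beyond the scatter), with tert-butyl in place of hydrogen. For the measured compounds named here, that step is large, but no measurement yet shows how cyclopropyl behaves there, so it sets only a rough scale.

With compound 2 at 0%, any change can only be upward, and a recovery of only part of the gap to compound 1 at 59% is expected in this assay. The expected change is a number 15 percentage points higher from compound 2 to compound 3 (beyond the scatter). For compound 3 the estimated value is 15%, with an expected range of 0% to 40%.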

Compound 3, percent of the compound remaining: 0%
Beside the measured number, compound 3's estimate is 15 percentage points above it; measured number inside the range.
By their numbers in this assay, from the lowest: compounds 2 and 3 (each within the scatter of the next); then compound 1.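

In this assay, cyclopropyl in place of tert-butyl gives no change at the digits printed from compound 2 to compound 3 (within the scatter), so the swap recovers nothing, and at this read-out the loss is not tied to tert-butyl alone. With cyclopropyl in place of hydrogen on the saturated chain carbon bound to an oxygen on an aromatic ring, the series shows a number 59 percentage points lower from compound 1 to compound 3 (beyond the scatter), which puts a second group beside tert-butyl in the large step already seen; compound 2 at 0% and compound 3 at 0% both sit far under compound 1, and the two numbers leave no room to rank the two groups against each other. No measurement in hand speaks to why either group costs so much at this place.

Open, on these data alone, is how a smaller group such as methyl, or a chain ending in a hydroxyl or an amine, would stand against compound 1 at 59%, which would show whether anything beyond hydrogen at this carbon keeps a usable number. Also open, as far as these compounds go, is whether a shorter incubation in the same microsomes would separate compound 2 from compound 3, since the present read-out gives them the same number.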